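A few compounds are considered here, and "the series" means these few. Any claim that something is new, unique, unknown or untested is made for them only; others in the source may bear on it.

Working notes on the series. Compound 1 `Oc1ccc(-c2cc(-c3cccs3)cc(-c3ccccc3O)n2)cc1` gives in an assay on isolated protein for inhibition of DNA topoisomerase 1 (Homo sapiens), with a stated time of 30 min, tested at 100 uM (a lower number here means a weaker effect, a higher number a stronger effect of the compound at the concentration tested), a value of 72.2%. Compound 2 `Oc1ccc(-c2cc(-c3cccs3)cc(-c3cccc(O)c3)n2)cc1` differs from it by 3-hydroxyphenyl in place of 2-hydroxyphenyl on an aromatic carbon and in this assay compound 2 gives 85.7%; the step is a number 13.5 percentage points higher from compound 1 to compound 2 (beyond the scatter). Compound 3 `Oc1cccc(-c2cc(-c3ccccn3)cc(-c3ccccc3O)n2)c1` rests on a different core, and the difference between the two cores is not broken down here. In this assay compound 3 gives 35.4%, the lowest of the three numbers. Compound 4 `Oc1cccc(-c2cc(-c3ccccn3)cc(-c3cccc(O)c3)n2)c1` carries the same kind of change against compound 3, (3-hydroxyphenyl in place of 2-hydroxyphenyl on an aromatic carbon); the surroundings differ, the place being meta to a 3-hydroxyphenyl group and meta to a pyridin-2-yl group rather than meta to a 4-hydroxyphenyl group and meta to a thiophen-2-yl group. A step of similar size to a number 13.5 percentage points higher from compound 1 to compound 2 (beyond the scatter) is expected here, estimated as a number 13.6 percentage points higher from compound 3 to compound 4 (beyond the scatter), resting on that single precedent alone. Compound 4 is accordingly expected to give about 49%, plausibly between 32% and 66%.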

Compound 4, a percentage reported as inhibition, at one concentration (the size of the read-out at that concentration, not a potency): 8.3%
Beside the measured number, compound 4's estimate is 40.7 percentage points above it; measured number below the stated range.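

In this assay, the change of 2-hydroxyphenyl to 3-hydroxyphenyl gives a number 27.1 percentage points lower from compound 3 to compound 4 (beyond the scatter), so this change cannot be carried from one core to the other with its direction or size kept: the same change on two cores in this assay, a number 13.5 percentage points higher (beyond the scatter) from compound 1 to compound 2 and a number 27.1 percentage points lower (beyond the scatter) from compound 3 to compound 4, 40.6 percentage points apart, beyond the scatter of two such steps. The result rests on one pair per core and sets no rule for any further core. It also does not show which difference between the cores goes with the reversal, since the thiophen-2-yl and pyridin-2-yl groups and the 4-hydroxyphenyl and 3-hydroxyphenyl groups vary together.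

The compounds shown leave open how each of these groups acts when varied alone. They also leave open how an amine or a carboxylic acid in place of the hydroxyl group would read.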